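The source may report more compounds than this note shows. Statements on the series, on what has been measured and on what is new or still open speak of the compounds shown alone.

Compound 1, `Cn1c(-c2ccccc2C(F)(F)F)nnc1C12CCC(COc3ccc(S(C)(=O)=O)cc3)(CC1)CC2`: in an assay on CHO-K1 cells for inhibition of 11-beta-hydroxysteroid dehydrogenase type 2 (Mus musculus), read by scintillation proximity assay (on this read-out lower numbers stand for stronger inhibition and higher numbers for weaker inhibition), compound 1 gives > 4000 nM, which is a limit of the assay.
Compound 2, `CCS(=O)(=O)CCC12CCC(c3nnc(-c4ccccc4Br)n3C)(CC1)CC2`: in this assay compound 2 gives > 4000 nM, also a limit.
Compound 3, `CCS(=O)(=O)CCC12CCC(c3nnc(-c4ccccc4C)n3C)(CC1)CC2`: in this assay compound 3 gives > 4000 nM, also a limit.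

Compound 1 therefore stands at the limit of this assay, the place where every value shown sits (the limit of > 4000 nM in this assay, at which 3 of the 3 values shown sit), and no number separates it from compound 2 or compound 3. Compound 4, `CCS(=O)(=O)CCCCC12CCC(c3nnc(-c4ccccc4C(F)(F)F)n3C)(CC1)CC2`, differs from compound 1 by 3-(ethylsulfonyl)propyl in place of 4-(methylsulfonyl)phenoxy on a saturated chain carbon bound to a saturated ring carbon. For the measured compounds named here, the only measured step between two compounds is a step that the two limits leave unreadable from compound 2 to compound 3, which the limits leave unreadable, and it alters a group on the aromatic ring of the core rather than the chain that differs between compound 1 and compound 4; no measured step bears directly on this change. Compound 2 and compound 3, which like compound 4 lack the aromatic ring of the 4-(methylsulfonyl)phenoxy group, both sit at the limit. Because every value shown is a limit (the limit of > 4000 nM in this assay, at which 3 of the 3 values shown sit), nothing measured points to a gain in this assay for compound 4. The expected step is a step that the limit leaves unreadable from compound 1 to compound 4, none beyond the scatter, as both values are expected to be limits. For compound 4 the estimate in this assay is 8000 nM, ranging from 3000 nM to 30000 nM.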

Compound 4, half-maximal inhibitory concentration: > 4000 nM
Compound 4: no number, only a limit (the forecaster's own chance of this, stated with the estimate: 85%); the middle value lies beyond the limit too.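

Compound 1 and compound 4 both stand at a limit in this assay, so the step between them cannot be read. The compounds shown leave open how far any change among them alters inhibition, as no value here is a number: the limit of > 4000 nM in this assay, at which 4 of the 4 values shown sit.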